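Bromo in place of hydroxymethyl on the core of compound 1

The source may hold more compounds than are shown below. What is called first, only, known or untested is meant among the compounds shown, and "the series" means these compounds.

Compound 1, `CN1CCC[C@H]1[C@@H]1COc2ccc(CO)cc2O1`, gives 51000 nM in an assay on Cerebral cortex (strain Sprague-Dawley) for displacement of a labelled ligand from Neuronal acetylcholine receptor; alpha4/beta2 (Rattus norvegicus); a lower number here means a stronger inhibitor, a higher number a weaker inhibitor. Among the two numbers known so far it has the highest one; its only neighbour is compound 2, `CN1CCC[C@H]1[C@H]1COc2ccc(CO)cc2O1`, which in this assay gives 9500 nM. For the measured compounds named here, the one step between them, a 5.4-fold lower number from compound 1 to compound 2 (0.73 log units; beyond the scatter), rests on the fact that compounds 1 and 2 differ only in the configuration as drawn alone, since the two share every atom and bond.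

Compound 3, `CN1CCC[C@H]1[C@@H]1COc2ccc(Br)cc2O1`, differs from compound 1 in another way: bromo in place of hydroxymethyl on an aromatic carbon. Going by the values given here, none of the measured steps touches the substituent on the aromatic ring, and the configurational step from compound 1 to compound 2 says nothing about what a bromo group does where a hydroxymethyl stood. There is therefore no measured basis for predicting a move in either direction, and the expectation for compound 3 is a number close to that of compound 1, with a wide range to reflect how little is known.

Compound 3 is thus estimated to give 40000 nM in this assay, between 8000 nM and 200000 nM, which means an expected step of a 1.3-fold lower number from compound 1 to compound 3 (0.11 log units; within the scatter).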

Compound 3, inhibition constant: 8100 nM
The estimate for compound 3 lay 4.9-fold (0.69 log units) above the measured number; the range from low to high includes it.
By their numbers in this assay, from the lowest: compounds 3 and 2 (each within the scatter of the next); then compound 1.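

In this assay, putting bromo in place of hydroxymethyl on this aromatic carbon gives a 6.3-fold lower number from compound 1 to compound 3 (0.80 log units; beyond the scatter), so a position that the earlier pair left untouched does respond to the group it carries, in a step of modest size. The exchange swaps a group with one hydrogen-bond donor and one hydrogen-bond acceptor for one with neither, and it also takes the substituent from two heavy atoms to one, so this single step cannot separate these differences from one another or from the identity of bromine itself. For the compounds shown here, the only other measured comparison concerns configuration at a saturated ring carbon and offers no explanation for what happens when the aromatic substituent changes.

Going by these compounds, it remains open how an amine, a carboxylic acid or a longer chain on this aromatic carbon would stand against bromo and hydroxymethyl in this assay. Also open, on these data alone, is whether bromo in place of hydroxymethyl on the core of compound 2 would bring a step of similar size, which would show whether the change of substituent and the change of configuration act independently.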